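A few compounds are considered here, and "the series" means these few. Any claim that something is new, unique, unknown or untested is made for them only; others in the source may bear on it.

In a functional assay on HepG2 cells (Homo sapiens) for inhibition, read by MTT assay, with a stated time of 72 h (a lower number here means a stronger inhibitor, a higher number a weaker inhibitor), three compounds sharing one core have been measured. Compound 1 `Cc1ccccc1-c1cc(C(=O)N2CCC3(CC2)CC(=O)c2nn(C(C)(C)C)cc2O3)c2ccccc2n1` returns only a limit of the assay, > 10000 nM. Compound 2 `CC(C)(C)n1cc2c(n1)C(=O)CC1(CCN(C(=O)c3cc(-c4ccc(F)cc4)nc4ccccc34)CC1)O2` gives 2930 nM. Compound 3 `CC(C)(C)n1cc2c(n1)C(=O)CC1(CCN(C(=O)c3cc(-c4ccc(N)cc4)nc4ccccc34)CC1)O2` gives 630 nM, the lowest number of the three. Compound 4 `COc1cc(C(=O)N2CCC3(CC2)CC(=O)c2nn(C(C)(C)C)cc2O3)c2ccccc2n1` differs from it as follows: methoxy in place of 4-aminophenyl on an aromatic carbon, with methoxy in place of 4-aminophenyl next to the ring nitrogen. All measured steps fall on this same carbon, and each keeps an aromatic ring there. They are an at least 3.4-fold lower number from compound 1 to compound 2 (0.53 log units; beyond the scatter), an at least 15-fold lower number from compound 1 to compound 3 (1.20 log units; beyond the scatter) and a 4.7-fold lower number from compound 2 to compound 3 (0.67 log units; beyond the scatter). Since compound 3 owes its standing to the step of a 4.7-fold lower number from compound 2 to compound 3 (0.67 log units; beyond the scatter), losing 4-aminophenyl is expected to raise the number by a modest to large step in this assay. The expected change is a 6.3-fold higher number from compound 3 to compound 4 (0.80 log units; beyond the scatter). For compound 4 the estimate is 4000 nM, within a range of 1200 nM to 14000 nM.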

Compound 4, half-maximal inhibitory concentration: > 10000 nM
Compound 4 gave a limit, no number (the forecaster's own chance of this, stated with the estimate: 30%); at least 2.5-fold (0.39 log units) between middle value and limit.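

Among the compounds shown here, this is the first change at this carbon that leaves no aromatic ring there, and in this assay it brings an at least 15-fold higher number from compound 3 to compound 4 (1.20 log units; beyond the scatter) and an at least 3.4-fold higher number from compound 2 to compound 4 (0.53 log units; beyond the scatter). Both steps are lower bounds, as compound 4 gives only a limit and not a number. Compound 1 also gives a limit, so the step between compound 1 and compound 4 cannot be read: the limit of > 10000 nM in this assay, at which 2 of the 4 values shown sit.

As far as these compounds go, it remains open whether a small group without a ring, such as dimethylamino, would give a number at this carbon. From the compounds shown here alone, it is equally open how an unsubstituted phenyl or a 4-hydroxyphenyl ring would compare with 4-aminophenyl.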